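A ring swap among compounds that sit at the limit

The source may hold more compounds than are shown below. What is called first, only, known or untested is meant among the compounds shown, and "the series" means these compounds.

In a toxicity assay on HT-29 cells (Homo sapiens) for cytotoxicity (a higher number here means that more compound is tolerated, a lower number that less compound is tolerated), compound 1 `CCCCn1nc(C(=O)N[C@H]2COc3ccccc3N(C)C2=S)nc1Cc1ccccc1` gives > 100000 nM and this is a limit, not a number. Compound 2 `CC(C)Cn1nc(C(=O)N[C@H]2COc3ccccc3N(C)C2=S)nc1Cc1ccccc1` gives > 100000 nM and this too is a limit. Compound 3 `CN1C(=S)[C@@H](NC(=O)c2nc(Cc3ccccc3)n(CC3CCOCC3)n2)COc2ccccc21` stands at > 100000 nM which is likewise a limit, so it has no number of its own. The whole record is the limit of > 100000 nM in this assay, at which 3 of the 3 values shown sit, and nothing more.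

Compound 4 `CN1C(=S)[C@@H](NC(=O)c2nc(Cc3ccccc3)n(C3CCNCC3)n2)COc2ccccc21` carries piperidin-4-yl in place of (oxan-4-yl)methyl on an aromatic nitrogen. The measured steps that bear on this position are a step that the two limits leave unreadable from compound 1 to compound 2 and a step that the two limits leave unreadable from compound 1 to compound 3 and a step that the two limits leave unreadable from compound 2 to compound 3 and none of them has a readable size. None of these compounds carries piperidin-4-yl, so the expectation is loose. No shift beyond the scatter is expected in this assay in either direction. The expected step is a number no higher from compound 3 to compound 4 (the limit leaves the size open) as an estimate only. For compound 4 the estimated value is 100000 nM with an expected range from 30000 nM to 200000 nM in this assay.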

Compound 4, half-maximal cytotoxic concentration: > 100000 nM
Compound 4: a limit, no number; the forecaster's own chance of this, stated with the estimate: 70%; the middle value sits exactly at the limit.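

In this assay compound 4 gives > 100000 nM, which is a limit and not a number. No new step can be read from compound 1, compound 2 or compound 3 to compound 4: the limit of > 100000 nM in this assay, at which 4 of the 4 values shown sit. The compounds shown leave open whether the groups on the aromatic nitrogen differ at all in this assay.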